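This account rests on a few compounds, and the source may have more. Where it says the series, first, only, none or still open, it means among the compounds named here.

Measured so far in a functional assay on CHO cells for positive allosteric modulation of muscarinic acetylcholine receptor M5 (Homo sapiens), read by calcium flux; a lower number here means a smaller maximal response, a higher number a larger maximal response:
compound 1, `CCCN(Cc1ccccc1C(F)(F)F)C(=O)C1CCN(S(=O)(=O)c2ccc3[nH]ncc3c2)CC1`: 94%
compound 2, `CC(C)N(Cc1ccccc1C(F)(F)F)C(=O)C1CCN(S(=O)(=O)c2ccc3[nH]ncc3c2)CC1`: 54%

Compound 2 holds the lower of the two numbers, the step of a number 40 percentage points lower from compound 1 to compound 2 (beyond the scatter) lying beyond the scatter. Compound 3, `O=C(C1CCN(S(=O)(=O)c2ccc3[nH]ncc3c2)CC1)N(CCO)Cc1ccccc1C(F)(F)F`, carries one change: 2-hydroxyethyl in place of isopropyl on an amide-type nitrogen. For the measured compounds named here, no measured step touches a hydroxyethyl group, and the single step from propyl to isopropyl shows only that this amide-type nitrogen is sensitive to what it bears. Compound 3 is therefore expected to give 72%, between 45% and 100%. The expected step is a number 18 percentage points higher from compound 2 to compound 3 (beyond the scatter), upward but uncertain.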

Compound 3, largest response reached (reported as percent of maximum), in percent of the reference or control that the assay uses: 60%
Compound 3: the middle estimate sits 12 percentage points above what was measured, and the stated range covers the measured number.
By their numbers in this assay, from the lowest: compounds 2 and 3 (each within the scatter of the next); then compound 1.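

In this assay, 2-hydroxyethyl in place of isopropyl on the amide-type nitrogen gives a number 6 percentage points higher from compound 2 to compound 3 (within the scatter) and so leaves these two groups indistinguishable at this position. Hydroxy in place of methyl on a saturated chain carbon, two bonds along the chain from the amide-type nitrogen, gives a number 34 percentage points lower from compound 1 to compound 3 (beyond the scatter) and shows that an unbranched chain alone does not secure the high response. No measurement shown accounts for either step.

Still open, on these data alone, is how a butyl chain, an ethyl group or a 2-methoxyethyl group would read at this nitrogen. Also open, as far as these compounds go, is whether a 2-aminoethyl group would read with compound 1 or with compound 3.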